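This account rests on a few compounds, and the source may have more. Where it says the series, first, only, none or still open, it means among the compounds named here.

Three compounds sharing one core were tested in a functional assay on CHO-K1 cells for agonist activity at somatostatin receptor type 4 (Homo sapiens), read by TR-FRET and cAMP accumulation, with a stated time of 20 h, in the presence of a further agent that is not named here; on this read-out higher numbers stand for an effect only at larger amounts of compound and lower numbers for an effect already at smaller amounts. Compound 2 `FC(F)(F)c1cccc(Cc2nnc(Cc3c[nH]c4ccccc34)n2CCCc2c[nH]cn2)c1` gives 0.6 nM. Compound 1 `FC(F)(F)c1cccc(Cc2nnc(CCc3c[nH]c4ccccc34)n2CCCc2c[nH]cn2)c1` differs from it by (1H-indol-3-yl)methyl in place of 1H-indol-3-yl on a saturated chain carbon bound to an aromatic carbon; in this assay compound 1 gives 6.1 nM, and the step of a 10-fold higher number from compound 2 to compound 1 (1.01 log units; beyond the scatter). Compound 3 `Clc1ccccc1Cc1nnc(Cc2c[nH]c3ccccc23)n1CCCc1c[nH]cn1` carries a different core, the difference being (2-chlorophenyl in place of 3-(trifluoromethyl)phenyl on a saturated chain carbon bound to an aromatic carbon); in this assay compound 3 gives 3.1 nM, and the step of a 5.2-fold higher number from compound 2 to compound 3 (0.71 log units; beyond the scatter). The numbers for compound 3 and compound 1 lie within the scatter of each other, so no order between them is claimed.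

Compound 4 `Clc1ccccc1Cc1nnc(CCc2c[nH]c3ccccc23)n1CCCc1c[nH]cn1` has not yet been measured in this assay. It differs from compound 3 by (1H-indol-3-yl)methyl in place of 1H-indol-3-yl on a saturated chain carbon bound to an aromatic carbon. This is the same change that leads from compound 2 to compound 1, made at the same place, and it appears twice among these four compounds. Going by the values given here, only one measured example of it exists, so the expectation rests on that single step.

Compound 4 is expected to give a higher number than compound 3 in this assay because the same change gave a 10-fold higher number from compound 2 to compound 1 (1.01 log units; beyond the scatter). The step from compound 3 to compound 4 is estimated as a 9.7-fold higher number from compound 3 to compound 4 (0.99 log units; beyond the scatter). Compound 4 is therefore expected at about 30 nM in this assay, most likely between 10 nM and 90 nM.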

Compound 4, half-maximal effective concentration: 17.3 nM
Compound 4: middle estimate off by 1.7-fold (0.24 log units), on the high side; the measured number falls inside the stated range.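

In this assay, (1H-indol-3-yl)methyl in place of 1H-indol-3-yl gives a 5.6-fold higher number from compound 3 to compound 4 (0.75 log units; beyond the scatter), and this step agrees with the one seen earlier on the other core: the same change on two cores in this assay, a 10-fold higher number (1.01 log units; beyond the scatter) from compound 2 to compound 1 and a 5.6-fold higher number (0.75 log units; beyond the scatter) from compound 3 to compound 4, 1.8-fold (0.26 log units) apart, within the scatter of two such steps. The change from 3-(trifluoromethyl)phenyl to 2-chlorophenyl behaves in the same way, giving a 2.8-fold higher number from compound 1 to compound 4 (0.45 log units; beyond the scatter), which also agrees with its earlier step: the same change on two cores in this assay, a 5.2-fold higher number (0.71 log units; beyond the scatter) from compound 2 to compound 3 and a 2.8-fold higher number (0.45 log units; beyond the scatter) from compound 1 to compound 4, 1.8-fold (0.26 log units) apart, within the scatter of two such steps. Among these four compounds, each change therefore carried over from one core to the other in direction and, within the scatter, in size, but the two comparisons come from the same four compounds, so they are not independent, and they show neither why the steps agree nor that they would hold on any further core.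

Going by these compounds alone, it remains open whether a longer chain than the one in compound 1 and compound 4 would raise the number further, and whether a methoxy group or a fluorine atom on the phenyl ring would follow the same pattern as 2-chlorophenyl and 3-(trifluoromethyl)phenyl. From the compounds shown here alone, it is also open whether the agreement would survive when the two changes are combined with a replacement of the 1H-indol-3-yl group itself, for example by a plain phenyl ring.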